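This account rests on a few compounds, and the source may have more. Where it says the series, first, only, none or still open, it means among the compounds named here.

Measured compounds in a functional assay on HCC827 cells (Homo sapiens) for antiproliferative activity, read by MTT assay, with a stated time of 72 h; a higher number here means a weaker inhibitor, a lower number a stronger inhibitor:
- compound 1 `CN1CCN(c2ccc(Nc3ncc4nc(Nc5ccccc5)n([C@@H]5CCN(C(=O)OC(C)(C)C)C5)c4n3)cc2)CC1` gives 12 nM
- compound 2 `CN1CCN(c2ccc(Nc3ncc4nc(Nc5ccc(F)cc5)n([C@@H]5CCCNC5)c4n3)cc2)CC1` gives 120 nM
- compound 3 `CN1CCN(c2ccc(Nc3ncc4nc(Nc5ccccc5)n([C@@H]5CCNC5)c4n3)cc2)CC1` gives 65 nM

Compound 2 carries the highest of the three numbers in this assay. Its nearest neighbour is compound 3, whose value lies within the scatter of that of compound 2, so no order between those two can be claimed; compound 1 sits furthest away, beyond the scatter.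

The unmeasured compound 4 `CN1CCN(c2ccc(Nc3ncc4nc(Nc5ccc(F)cc5)n([C@@H]5CCN(S(=O)(=O)C6CC6)C5)c4n3)cc2)CC1` differs from compound 2 in one place: 1-(cyclopropylsulfonyl)pyrrolidin-3-yl in place of piperidin-3-yl on an aromatic nitrogen.

Within the data shown here, one measured step bears on this change. Between compound 1 and compound 3 the ring amine nitrogen passes from a carbonyl-type cap to a free hydrogen, and this gives a 5.4-fold higher number from compound 1 to compound 3 (0.73 log units; beyond the scatter). The change from compound 2 to compound 4 runs the other way, capping the ring amine, here with a sulfonyl group and at the same time shrinking the ring; the step from compound 1 to compound 3 is therefore only a partial guide. On that basis a modest lowering of the number in this assay is expected, of a size similar to that step. The expected step is thus a 4.0-fold lower number from compound 2 to compound 4 (0.60 log units; beyond the scatter). Compound 4 is estimated at 30 nM in this assay, with a range from 10 nM to 100 nM.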

Compound 4, half-maximal inhibitory concentration: 2.5 nM
Compound 4: the middle estimate sits 12-fold (1.08 log units) above what was measured; measured number below the stated range.
By their numbers in this assay, from the lowest: compound 4; then compound 1; then compounds 3 and 2 (each within the scatter of the next).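

In this assay, replacing piperidin-3-yl with 1-(cyclopropylsulfonyl)pyrrolidin-3-yl on the aromatic nitrogen gives a 48-fold lower number from compound 2 to compound 4 (1.68 log units; beyond the scatter). This position therefore accepts a group of 11 heavy atoms and 0 hydrogen-bond donors in place of one of 6 heavy atoms and 1 donor, and the number falls rather than rises. Until now the only capped ring amine was the tert-butoxycarbonyl one, whose removal gives a 5.4-fold higher number from compound 1 to compound 3 (0.73 log units; beyond the scatter); the new step shows that a sulfonyl cap can also accompany a low number, and with a larger step, though that step also includes a change in ring size and the 4-fluorophenyl series differs from the phenyl one. No measurement available here accounts for the size of the step.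

As far as these compounds go, how the step divides between the smaller ring and the cap stays open, since the two change together from compound 2 to compound 4. Also open, from the compounds shown here alone, is whether a methylsulfonyl or acetyl cap on the same ring nitrogen, or a cyclopropylsulfonyl cap on the piperidin-3-yl ring, would behave as the 1-(cyclopropylsulfonyl)pyrrolidin-3-yl group does.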